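Notes on the aryl group of the triazole in this series

The source may hold more compounds than are shown below. What is called first, only, known or untested is meant among the compounds shown, and "the series" means these compounds.

Compound 1 `O=c1[nH]cc(S(=O)(=O)Nc2ccccc2-c2cn(-c3ccccc3)nn2)c(=O)[nH]1` is the parent. In a functional assay on OVCAR-3 cells (Homo sapiens) for antiproliferative activity, read by MTT assay, with a stated time of 24 h (a lower number here means a stronger inhibitor, a higher number a weaker inhibitor), compound 1 gives 6650 nM. Compound 2 `O=c1[nH]cc(S(=O)(=O)Nc2ccccc2-c2cn(-c3ccc(F)cc3)nn2)c(=O)[nH]1` carries a fluoro in place of hydrogen on an aromatic carbon. In this assay compound 2 is reported only as a limit of the assay, > 20000 nM, not as a number (the limit of > 20000 nM in this assay, at which 1 of the 2 values shown sits). The step of an at least 3.0-fold higher number from compound 1 to compound 2 (0.47 log units; beyond the scatter) is accordingly known only as a lower bound, and compound 2 stands at the weaker end of the two values shown.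

Compound 3 `O=c1[nH]cc(S(=O)(=O)Nc2ccccc2-c2cn(-c3ccccc3Cl)nn2)c(=O)[nH]1` is the next member and has not yet been measured in this assay. It differs from compound 2 by 2-chlorophenyl in place of 4-fluorophenyl on an aromatic nitrogen. Among the measured compounds shown here, the single measured step, hydrogen to fluoro, concerns another halogen at another ring carbon and does not bear directly on this change, so no measured step sets its size or direction.

Compound 3 is estimated in this assay at 15000 nM, with a range from 5000 nM to 40000 nM. The expected step of an at least 1.3-fold lower number from compound 2 to compound 3 (0.12 log units; that floor lies within the scatter) is taken from the limit of the assay and is therefore uncertain; a further limit is a real possibility.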

Compound 3, half-maximal inhibitory concentration: 3170 nM
Compound 3: middle estimate off by 4.7-fold (0.68 log units), on the high side, and the stated range ends above it.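

Among the compounds shown here, a chloro on the phenyl gives a 2.1-fold lower number from compound 1 to compound 3 (0.32 log units; beyond the scatter) in this assay, the first change on this aryl group to move toward a stronger inhibitor; a halogen on the phenyl therefore does not always weaken the compound, and compound 2 is the member that goes the other way. 2-Chlorophenyl in place of 4-fluorophenyl on the aromatic nitrogen gives an at least 6.3-fold lower number from compound 2 to compound 3 (0.79 log units; beyond the scatter), which places the two halogen-bearing members on opposite sides of compound 1 and shows that this aryl group can move the read-out in either direction. That step is known only as a lower bound, as the value of compound 2 is a limit of the assay and not a number: the limit of > 20000 nM in this assay, at which 1 of the 3 values shown sits.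

The halogen and its ring carbon remain unseparated, as compound 2 and compound 3 differ in both. Also open, going by these compounds, is how this assay would read with an amine, a carboxylic acid or a methoxy group on this phenyl, and whether any such group would take the series beyond the level of compound 3.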